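Swapping a Ring Amine for Diethylamino on a Benzamide

The source may hold more compounds than are shown below. What is called first, only, known or untested is meant among the compounds shown, and "the series" means these compounds.

Measured so far, in a functional assay on Jurkat cells (Homo sapiens) for cytotoxicity, read by MTT assay, with a stated time of 48 h; on this read-out higher numbers stand for weaker inhibition and lower numbers for stronger inhibition:
Compound 1 `O=C(Nc1cc(C(F)(F)F)ccc1N1CCCC1)c1cccnc1` gives "not active" (no number reported).
Compound 2 `O=C(Nc1cc(C(F)(F)F)ccc1NC1CCCCC1)c1ccccc1` gives "not active" (no number reported).
Compound 3 `O=C(Nc1cc(C(F)(F)F)ccc1NC1CCCCC1)c1ccncc1` gives 80900 nM.

Compound 2 stands without a number; its result is only a statement of no activity, and compound 1 shares that outcome. Compound 3 alone gives a number, and it is a very weak one. The next compound, compound 4 `CCN(CC)c1ccc(C(F)(F)F)cc1NC(=O)c1ccccc1`, differs from compound 2 by diethylamino in place of cyclohexylamino on an aromatic carbon. Within the data shown here, no measured pair shows how this kind of change shifts the read-out, so the expectation rests on compound 2 at "not active" (no number reported) and on compound 3 at 80900 nM. The step from compound 2 to compound 4 is expected to be small, or none beyond the scatter, with compound 4 staying very weak. Compound 4 is estimated at 100000 nM in this assay, within 30000 nM to 300000 nM, and quite possibly again only a statement of no activity.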

Compound 4, half-maximal inhibitory concentration: "not active" (no number reported)
Compound 4: no number reported; no gap can be computed for the estimate.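

In this assay, among these compounds, compound 2 and compound 4 both lack a number, so no step between them can be read. No supporting data explain this result. From the compounds shown here alone, whether diethylamino and cyclohexylamino differ in effect remains open.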